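From compound 1 to compound 4: a side-chain swap

This account rests on a few compounds, and the source may have more. Where it says the series, first, only, none or still open, it means among the compounds named here.

In an ADME assay on CCRF-CEM cells (Homo sapiens) for cytotoxicity, with a stated time of 5 days (a higher number here means a weaker inhibitor, a lower number a stronger inhibitor), compound 1 `[N-]=[N+]=N[C@H]1C[C@H](n2cnc3c(NCCCCCO)nc(N)nc32)O[C@@H]1CO` gives > 100000 nM, which is a limit of the assay and not a number. Compound 2 `COc1nc(N)c2ncn([C@H]3C[C@H](N=[N+]=[N-])[C@@H](CO)O3)c2n1` also gives only a limit, > 100000 nM. Compound 3 `[N-]=[N+]=N[C@H]1C[C@H](n2cnc3c(N)nc(F)nc32)O[C@@H]1CO` does give a number, 30100 nM.

Compound 4 `C=CCN(C)c1nc(N)nc2c1ncn2[C@H]1C[C@H](N=[N+]=[N-])[C@@H](CO)O1` has not been measured yet. It differs from compound 1 as follows: allyl(methyl)amino in place of (5-hydroxypentyl)amino on an aromatic carbon. In words, allyl(methyl)amino stands in place of (5-hydroxypentyl)amino on an aromatic carbon.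

Within the data shown here, no measured step makes this exact exchange. The nearest guide is an at least 3.3-fold lower number from compound 2 to compound 3 (0.52 log units; beyond the scatter), a step beyond the scatter, but it swaps different groups and so gives only a rough idea of size. The wider picture is the limit of > 100000 nM in this assay, at which 2 of the 3 values shown sit. On that basis, the expected change, an at least 1.2-fold lower number from compound 1 to compound 4 (0.09 log units; that floor lies within the scatter), is no clear step beyond the scatter, and if anything a slightly lower number. For compound 4 the estimated value is 80000 nM, with an expected range of 25000 nM to 200000 nM.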

Compound 4, half-maximal inhibitory concentration: 27000 nM
The estimate for compound 4 lay 3.0-fold (0.47 log units) above the measured number; measured number inside the range.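

Exchanging (5-hydroxypentyl)amino for allyl(methyl)amino gives an at least 3.7-fold lower number from compound 1 to compound 4 (0.56 log units; beyond the scatter). Among these compounds, this is the first sign in this assay that the group on this aromatic carbon can by itself shift the result, something the earlier step, a fluoro-for-methoxy exchange elsewhere on the shared core, could not show. The true size of the shift stays unknown, since the value for compound 1 is a limit and the step is only a floor: the limit of > 100000 nM in this assay, at which 2 of the 4 values shown sit.

The exchange alters several things at once, as the entering group has a double bond and 0 hydrogen-bond donors against 2 for the leaving group, so the compounds shown do not tell which of these differences matters. On these data alone, how a butylamino chain, a dimethylamino group or a hydroxyl-bearing allyl chain on this carbon would read out remains open.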